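This account rests on a few compounds, and the source may have more. Where it says the series, first, only, none or still open, it means among the compounds named here.

Three compounds built on a shared core have been examined in an assay on mitochondria (strain BALB/c) for inhibition of glycerol-3-phosphate acyltransferase 1, mitochondrial (Mus musculus), read by scintillation counting, with a stated time of 10 min; on this read-out higher numbers stand for weaker inhibition and lower numbers for stronger inhibition. Compound 1 `CCCCCCCCS(=O)(=O)Nc1cc(-c2ccc(Cl)cc2)ccc1C(=O)O` gives 18100 nM in this assay. Compound 2 `CCCCCCCCS(=O)(=O)Nc1ccc(-c2ccc(CCCC)cc2)cc1C(=O)O` gives 9000 nM in this assay, and compound 3 `CCCCCCCCS(=O)(=O)Nc1ccc(C(=O)c2ccc(-c3ccccc3)cc2)cc1C(=O)O` gives 13000 nM. Compound 1 carries the highest number of the three, yet its separation from compound 3 and from compound 2 lies within the scatter of repeated measurements, so these readings do not set the three apart.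

Compound 4 `CCCCCCCCS(=O)(=O)Nc1cc(/C=C/c2ccc(OC)cc2)ccc1C(=O)O` has not yet been measured. It differs from compound 1 in one place: 2-(4-methoxyphenyl)ethenyl in place of 4-chlorophenyl on an aromatic carbon. For the measured compounds named here, no pair of measured compounds differing in a single place is available to show how a change of this kind moves the read-out, and the three measured values themselves do not separate. The step expected here, a 1.2-fold lower number from compound 1 to compound 4 (0.08 log units; within the scatter), is therefore one within the scatter, in no particular direction. On that basis compound 4 is estimated at 15000 nM in this assay, within a range from 5000 nM to 50000 nM, an estimate to be set against the measurement when it arrives.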

Compound 4, half-maximal inhibitory concentration: 38700 nM
Compound 4: middle estimate off by 2.6-fold (0.41 log units), on the low side, within the range that was stated.
By their numbers in this assay, from the lowest: compounds 2, 3 and 1 (each within the scatter of the next); then compound 4.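

In this assay, for the compounds shown here, the exchange of 4-chlorophenyl for 2-(4-methoxyphenyl)ethenyl on this aromatic carbon, para to the carboxy group, gives a 2.1-fold higher number from compound 1 to compound 4 (0.33 log units; beyond the scatter) and so provides the first single-place comparison in the set, a modest step beyond the scatter toward weaker inhibition. The position therefore responds to what it carries, although this larger group still leaves a measurable half-maximal inhibitory concentration. The exchange adds heavy atoms, a double bond outside aromatic rings and a hydrogen-bond acceptor all at once, and nothing measured bears on which of these matters or explains the step.

The compounds shown do not separate the ethenyl link from the methoxy group, so it remains open how 4-methoxyphenyl or 2-(4-chlorophenyl)ethenyl would read at this position. Also open, as far as these compounds go, is how this position would respond to an amine or a carboxylic acid on the outer ring, and whether any group placed here could move the number lower rather than higher.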